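Hydroxy to methoxy on the 3-hydroxyphenyl group

This account rests on a few compounds, and the source may have more. Where it says the series, first, only, none or still open, it means among the compounds named here.

compound 1 `O=C(NCCCNc1cc(-c2cn(-c3ccccc3)nc2-c2cccc(O)c2)ccn1)Nc1ccc(F)cc1`: 2160 nM
compound 2 `O=C(NCCCNc1cc(-c2cn(-c3ccccc3)nc2-c2cccc(O)c2)ccn1)Nc1cccc(C(F)(F)F)c1`: 1870 nM

In a functional assay on OVCAR-3 cells (Homo sapiens) for antiproliferative activity, read by sulforhodamine B assay, with a stated time of 48 h (a lower number here means a stronger inhibitor, a higher number a weaker inhibitor), compound 1 gives 2160 nM, within the scatter of compound 2 at 1870 nM, so neither stands apart. Compound 3 `COc1cccc(-c2nn(-c3ccccc3)cc2-c2ccnc(NCCCNC(=O)Nc3ccc(F)cc3)c2)c1` has not yet been measured. It carries 3-methoxyphenyl in place of the 3-hydroxyphenyl of compound 1, with methyl in place of hydrogen on an oxygen on an aromatic ring. Among the compounds with values here, the one measured step, a 1.2-fold lower number from compound 1 to compound 2 (0.06 log units; within the scatter), changes a different place, the group on an amide-type nitrogen, and so bears only indirectly. Within the data shown here, no step at this oxygen has been measured, which leaves its size open. Only a small rise in the number is expected, with wide uncertainty in either direction. The expected step is a 1.3-fold higher number from compound 1 to compound 3 (0.11 log units; within the scatter). For compound 3 the estimated value is 2800 nM, with an expected range from 1100 nM to 7000 nM.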

Compound 3, half-maximal inhibitory concentration: 6180 nM
Estimate against measurement, compound 3: 2.2-fold (0.34 log units) below; low and high end bracket the measured number.
By their numbers in this assay, from the lowest: compounds 2 and 1 (each within the scatter of the next); then compound 3.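

Within the data shown here, the oxygen on the aromatic ring is the first place where a single change moves the number beyond the scatter: in this assay the change to methoxy gives a 2.9-fold higher number from compound 1 to compound 3 (0.46 log units; beyond the scatter) and so separates the two compounds, which the earlier change on the amide-type nitrogen did not do. Methyl in place of hydrogen on this oxygen therefore brings a modest loss of activity, with 4-fluorophenyl held constant on the amide-type nitrogen. No measurement at hand accounts for this loss. The compounds shown leave open whether an amine or a fluorine in place of the hydroxy group would keep the number of compound 1, and whether ethoxy would raise it further. They also leave open whether the same step would be of similar size with the 3-(trifluoromethyl)phenyl group of compound 2.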